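The source may hold more compounds than are shown below. What is called first, only, known or untested is meant among the compounds shown, and "the series" means these compounds.

Measured in a functional assay on RKOp27 cells (Homo sapiens) for cytotoxicity, read by MTT assay, with a stated time of 3 days; a higher number here means a weaker inhibitor, a lower number a stronger inhibitor:
- Compound 1 `N#Cc1c(NN)nc(SCc2nc3ccccc3[nH]2)nc1-c1ccccc1`: 2.55 nM
- Compound 2 `N#Cc1c(Nc2ccccc2)nc(SCc2nc3ccccc3[nH]2)nc1-c1ccccc1`: 4.9 nM

Compound 2 stands level with compound 1, the two numbers lying within the scatter of each other. Compound 3 `CNc1nc(SCc2nc3ccccc3[nH]2)nc(-c2ccccc2)c1C#N` differs from compound 2 by methyl in place of phenyl on a nitrogen on an aromatic ring. Among the measured compounds shown here, the one measured step at this nitrogen, a 1.9-fold higher number from compound 1 to compound 2 (0.28 log units; within the scatter), stayed within the scatter, so no change beyond the scatter is expected in this assay. The estimated step is a 1.3-fold lower number from compound 2 to compound 3 (0.11 log units; within the scatter). For compound 3 the expected value is 3.8 nM, with an estimated range of 1.2 nM to 12 nM.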

Compound 3, half-maximal inhibitory concentration: 3.7 nM
Compound 3: the middle estimate sits 1.0-fold (0.01 log units) above what was measured, and the stated range covers the measured number.
By their numbers in this assay, from the lowest: compounds 1, 3 and 2 (each within the scatter of the next).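

In this assay, methylamino in place of anilino on this nitrogen stays within the scatter (a 1.3-fold lower number from compound 2 to compound 3 (0.12 log units; within the scatter)), and methyl in place of amino does too (a 1.5-fold higher number from compound 1 to compound 3 (0.16 log units; within the scatter)). The six-membered aromatic ring of carbon only can therefore give way to a single methyl carbon on this nitrogen with no change that this assay can separate from the scatter. No measurement available here offers an explanation for this result. The compounds shown leave open whether a longer chain or a carboxylic acid on this nitrogen would also stay within the scatter.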